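A Distant Swap on the Shared Core and Its Expected Effect

The source may hold more compounds than are shown below. What is called first, only, known or untested is meant among the compounds shown, and "the series" means these compounds.

Compound 1 `COc1ccc(F)cc1CNCCCNc1ccnc2cc(C3CCCCC3)ccc12` stands level with compound 3 `FC(F)(F)c1ccc(-c2ccc3c(NCCCNCc4ccco4)ccnc3c2)cc1` in a physicochemical assay for acid dissociation, with compound 1 giving 9.47 and compound 3 giving 9.47; together these are the highest of three numbers. Compound 2 `COc1cccc(CNCCCNc2ccnc3cc(Oc4ccc(F)cc4)ccc23)c1O` lies nearest in structure yet furthest in the read-out, giving 9.28 in this assay, a gap that still sits within the scatter. Compound 4 `COc1ccc(-c2ccc3c(NCCCNCc4cc(F)ccc4OC)ccnc3c2)cc1` has not yet been measured. It differs from compound 1 in one place: 4-methoxyphenyl in place of cyclohexyl on an aromatic carbon. The change sits on an aromatic carbon of the shared core, away from the chain that carries the amines. Since compound 2 and compound 3 carry different groups there yet stay within the scatter of compound 1, no step beyond the scatter is expected: the step from a number 0.07 log units lower from compound 1 to compound 4 (within the scatter) should be small. Compound 4 is therefore expected to give about 9.4 in this assay, within 9.1 to 9.7.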

Compound 4, acid dissociation constant: 9.47
Beside the measured number, compound 4's estimate is 0.07 log units below it; low and high end bracket the measured number.
By their numbers in this assay, from the lowest: compounds 2, 1, 3 and 4 (each within the scatter of the next).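

In this assay, going by these compounds alone, putting 4-methoxyphenyl in place of cyclohexyl on this aromatic carbon gives no change at the digits printed from compound 1 to compound 4 (within the scatter) and offers the first comparison in which only this position differs. Here, an aromatic ring carrying one hydrogen-bond acceptor replaces a non-aromatic ring with none, and the read-out does not move beyond the scatter. Nothing available explains this result.

A carboxylic acid or an amine on this aromatic carbon remains untested among the compounds shown. So does a longer chain between the two amines.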